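The compounds below may be only part of what the source reports. "The series", "measured", "known", "first", "only" and "open" are said of these compounds alone.

Compound 1 `C#Cc1cccc(Nc2ncnc3cc(OC)c(OCCCCC(=O)Nc4ccc(S(N)(=O)=O)cc4)cc23)c1` — 7720 nM
Compound 2 `COc1ccc(Nc2ncnc3cc(OC)c(OCCCCC(=O)Nc4ccc(S(N)(=O)=O)cc4)cc23)cc1` — > 40000 nM

Two compounds carry numbers here. In a functional assay on A549 cells (Homo sapiens) for antiproliferative activity, read by MTT assay, with a stated time of 72 h (on this read-out lower numbers stand for stronger inhibition and higher numbers for weaker inhibition), compound 1 gives 7720 nM. Compound 2 reaches only a limit of the measurement, > 40000 nM, so no number is known for it (the limit of > 40000 nM in this assay, at which 1 of the 2 values shown sits). Within the data shown here, the single measured step, an at least 5.1-fold higher number from compound 1 to compound 2 (0.71 log units; beyond the scatter), thus carries the read-out from a number onto this limit, and compound 2 stands at the weak end of what has been seen.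

Compound 3 `COc1ccccc1Nc1ncnc2cc(OC)c(OCCCCC(=O)Nc3ccc(S(N)(=O)=O)cc3)cc12` has not yet been measured in this assay. It differs from compound 2 by 2-methoxyphenyl in place of 4-methoxyphenyl on a nitrogen on an aromatic ring. Among the measured compounds shown here, no measured step covers this change: the only step known concerns the exchange of 3-ethynylphenyl for 4-methoxyphenyl, not where the methoxy group sits within a methoxyphenyl, and it leaves compound 2 at a limit rather than a number, so even the starting point is uncertain. With nothing to argue for a gain, compound 3 is expected to remain near the weak end, with an expected step of an at least 1.3-fold lower number from compound 2 to compound 3 (0.12 log units; that floor lies within the scatter) that is not judged to reach beyond the scatter. Compound 3 is therefore estimated at 30000 nM, within a range from 8000 nM to 100000 nM, and it may well again return only a limit.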

Compound 3, half-maximal inhibitory concentration: 24100 nM
Compound 3: the middle estimate sits 1.2-fold (0.10 log units) above what was measured, and the stated range covers the measured number.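

Placing the methoxy group as 2-methoxyphenyl rather than 4-methoxyphenyl on the nitrogen gives a methoxyphenyl compound a measured number in this assay: compound 3 gives 24100 nM. Compound 2 remains a limit and not a number: the limit of > 40000 nM in this assay, at which 1 of the 3 values shown sits. On these data alone, the change between these two compounds can therefore be stated only as a floor, an at least 1.6-fold lower number from compound 2 to compound 3 (0.22 log units; that floor lies within the scatter), so its true size stays unknown, while the comparison with the ethynyl compound, a 3.1-fold higher number from compound 1 to compound 3 (0.49 log units; beyond the scatter), shows that 2-methoxyphenyl on this nitrogen still gives a weaker result than 3-ethynylphenyl, by a gap beyond the scatter.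

The compounds shown leave open whether the methoxy group is needed at all on this ring, since they offer no comparison with a plain phenyl, a hydroxyl, an ethoxy group or a chlorine on the same nitrogen. They also leave open how much of the result depends on the chain carrying the sulfonamide, as every compound here has the same chain and none has a shorter or longer one, or a carboxylic acid in place of the sulfonamide.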